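Adding a methyl to the active mirror-image form

A few compounds are considered here, and "the series" means these few. Any claim that something is new, unique, unknown or untested is made for them only; others in the source may bear on it.

In a functional assay on A-375 cells (Homo sapiens) for activation, with a stated time of 3 days (on this read-out higher numbers stand for an effect only at larger amounts of compound and lower numbers for an effect already at smaller amounts), compound 1 `O=C(Nc1ccc(-c2ccc[nH]2)cc1)[C@@H]1CCCN(Cc2ccc(F)c(F)c2)C1` gives 19900 nM and compound 2 `O=C(Nc1ccc(-c2ccc[nH]2)cc1)[C@H]1CCCN(Cc2ccc(F)c(F)c2)C1` gives 140 nM. There is a 140-fold lower number from compound 1 to compound 2 (2.15 log units; beyond the scatter), because of the fact that compounds 1 and 2 differ only in the configuration as drawn. Compound 2 therefore stands far from compound 1 but close to compound 3 `O=C(Nc1ccc(-c2ccc[nH]2)cc1F)[C@H]1CCCN(Cc2ccc(F)c(F)c2)C1`, which gives 100 nM.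

Compound 4 `Cc1cc(NC(=O)[C@H]2CCCN(Cc3ccc(F)c(F)c3)C2)ccc1-c1ccc[nH]1` keeps the configuration of compound 2 and carries one new group: methyl in place of hydrogen on an aromatic carbon. The large step between compound 1 and compound 2 concerns configuration, so it says little about this change. The closest guide is a 1.4-fold lower number from compound 2 to compound 3 (0.15 log units; within the scatter), where fluoro takes the place of hydrogen on an aromatic carbon. That is only a loose guide, since fluoro is not methyl, and no methyl has yet been measured in this series. A small step, not clearly beyond the scatter, is therefore expected, perhaps towards a slightly higher number: the expected step is a 1.2-fold higher number from compound 2 to compound 4 (0.08 log units; within the scatter). Compound 4 is estimated at 170 nM, with an expected range from 50 nM to 600 nM.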

Compound 4, half-maximal effective concentration: 3000 nM
Compound 4: the middle estimate sits 18-fold (1.25 log units) below what was measured, and the stated range ends below it.
By their numbers in this assay, from the lowest: compounds 3 and 2 (each within the scatter of the next); then compound 4; then compound 1.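

In this assay, a methyl ortho to the 1H-pyrrol-2-yl group gives a 21-fold higher number from compound 2 to compound 4 (1.33 log units; beyond the scatter), so a single added carbon at this position is enough to move the number far beyond the scatter. Compound 3 carries its fluoro on a different carbon of the same ring, which means that its result says little about this position and that not every replacement of hydrogen on this ring leaves the number in place. The compounds shown do not explain why this methyl has so large an effect.

On these data alone, it remains open whether a methoxy or an ethyl on this same carbon would raise the number as far. As far as these compounds go, it also remains open whether a methyl on the carbon bearing the fluoro in compound 3 would do the same.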